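The source may report more compounds than this note shows. Statements on the series, on what has been measured and on what is new or still open speak of the compounds shown alone.

Measured so far in an assay on isolated protein for displacement of a labelled ligand from metabotropic glutamate receptor 5 (Homo sapiens), with a stated time of 60 min, tested at 1 uM; on this read-out higher numbers stand for more inhibition at the one concentration tested (going by the name of the read-out) and lower numbers for less inhibition:

compound 1, `COc1ccc2ncc(S(=O)(=O)c3ccc(OC)c(Cl)c3)c(N3CCC(C)CC3)c2c1`: 21%
compound 2, `Cc1cc(C)cc(S(=O)(=O)c2cnc3ccc(F)cc3c2N2CCC(C)CC2)c1`: 83%

Of these two numbers compound 1 stands lowest; compound 2 sits higher, and the gap between the two lies beyond the scatter. The two compounds differ in several places at once, so no single change can be read from that pair; their values are all that is known.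

Compound 3, `COc1ccc2ncc(S(=O)(=O)c3ccc(OC)c(OC)c3)c(N3CCC(C)CC3)c2c1`, is the next compound for this assay. Against compound 1 the change is methoxy in place of chloro on an aromatic carbon, read one bond further out as 3-chloro-4-methoxyphenyl to 3,4-dimethoxyphenyl. For the measured compounds named here, no measured pair shows this change on the shared core, so the expectation for compound 3 rests on compound 1 alone. The step is expected to be a number 1 percentage points lower from compound 1 to compound 3 (within the scatter), not clearly beyond the scatter in either direction. Compound 3 is therefore estimated at 20%, within a range of 5% to 40%.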

Compound 3, a percentage reported as inhibition, at one concentration (the size of the read-out at that concentration, not a potency): -3%
Compound 3: middle estimate off by 23 percentage points, on the high side, outside the stated range (below it).
By their numbers in this assay, from the lowest: compound 3; then compound 1; then compound 2.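

In this assay, methoxy in place of chloro on this aromatic carbon, ortho to a methoxy group, gives a number 24 percentage points lower from compound 1 to compound 3 (beyond the scatter), so this position is not indifferent to the group it carries. Compound 3 at -3% shows that, with the rest of compound 1 held constant, the 3,4-dimethoxyphenyl variant leaves no detectable inhibition at the one concentration tested, a point that the unmatched pair of compound 1 and compound 2 could not establish. Nothing available explains the size of this step.

Going by these compounds, the step rests on a single pair, so whether it carries over to the substitution pattern of compound 2 remains open. On these data alone, it is also open how a fluoro, bromo, hydroxy or amino group at this same position would read against chloro and methoxy.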